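A few compounds are considered here, and "the series" means these few. Any claim that something is new, unique, unknown or untested is made for them only; others in the source may bear on it.

The measured compounds, all in an ADME assay on SNB-19 cells (Homo sapiens) for cytotoxicity, read by MTT assay, with a stated time of 24 h; a higher number here means that more compound is tolerated, a lower number that less compound is tolerated:

Compound 1 `C=C1CC[C@@H]2[C@](C)(CO)[C@H](O)CC[C@@]2(C)[C@@H]1C/C=C1/C(=O)OC[C@H]1Oc1c(Cl)cc(Cl)c2cccnc12`: 85200 nM
Compound 2 `C=C1CC[C@@H]2[C@](C)(CO)[C@H](O)CC[C@@]2(C)[C@@H]1C/C=C1/C(=O)OC[C@@H]1Oc1cccc2cccnc12`: 22700 nM
Compound 3 `C=C1CC[C@@H]2[C@](C)(CO)[C@H](O)CC[C@@]2(C)[C@@H]1C/C=C1/C(=O)OC[C@@H]1Oc1ccnc2ccccc12`: 61200 nM

Among these three numbers, compound 3 stands second highest. Within the data shown here, its nearest neighbour is compound 1, whose value lies within the scatter of that of compound 3; compound 2 stands furthest away, the step of a 2.7-fold higher number from compound 2 to compound 3 (0.43 log units; beyond the scatter) being the only single-place step these three compounds allow, and it comes from the exchange of one quinolinyl attachment point for another.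

Compound 4 `C=C1CC[C@@H]2[C@](C)(CO)[C@H](O)CC[C@@]2(C)[C@@H]1C/C=C1/C(=O)OC[C@H]1Oc1ccnc2ccccc12` is the next compound. It differs from compound 3 as follows: the two compounds have the same atoms and bonds and differ only in configuration as drawn: 1 of 7 stereo elements differ; a stereocentre at a saturated ring carbon is drawn R in compound 3 and S in compound 4. Among the measured compounds shown here, no measured step among the three compounds concerns a change in configuration alone: the one step that is known, from compound 2 to compound 3, changes the aryl group, not a stereocentre, and compound 1 and compound 2 differ in more than one place, so their two values give no isolated reading on configuration. There is therefore nothing in the data pointing in either direction for this assay, and the expected step of no change at the digits printed from compound 3 to compound 4 (within the scatter) is none beyond the scatter. Compound 4 is accordingly estimated at 61200 nM in this assay, with a range from 25000 nM to 150000 nM.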

Compound 4, half-maximal cytotoxic concentration: 60100 nM
Compound 4: middle estimate off by 1.0-fold (0.01 log units), on the high side, and the stated range covers the measured number.
By their numbers in this assay, from the lowest: compound 2; then compounds 4, 3 and 1 (each within the scatter of the next).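

In this assay, among these compounds, turning the stereocentre at the saturated ring carbon from R to S with quinolin-4-yl in place gives a 1.0-fold lower number from compound 3 to compound 4 (0.01 log units; within the scatter), the first reading on configuration alone, and at this centre it separates nothing beyond the scatter. That reading is a clean one, and what it rests on is this: the fact that compounds 3 and 4 differ only in the configuration as drawn. With the configuration of this centre as drawn in the dichloro compound, quinolin-4-yl in place of 5,7-dichloroquinolin-8-yl gives a 1.4-fold lower number from compound 1 to compound 4 (0.15 log units; within the scatter), so this exchange of aryl groups also stays within the scatter.

From the compounds shown here alone, whether the stereocentre is equally silent with the quinolin-8-yl of compound 2 remains open, as that compound has no partner of opposite configuration here. Also open, going by these compounds, is how an amine or a carboxylic acid would read at this carbon in place of the quinolinyl ether.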